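Replacing the ester of compound 3 with a hydroxymethyl group

The compounds below may be only part of what the source reports. "The series", "measured", "known", "first", "only" and "open" are said of these compounds alone.

Compound 1 `CCc1cccc2c(OC)c(-c3occ(C)c3C(=O)OC)ccc12`: 1.7 ug/mL
Compound 2 `CCc1cccc2c(OC)c(-c3occ(C)c3C(=O)NC)ccc12`: > 10 ug/mL (a limit)
Compound 3 `CCOc1c(-c2occ(C)c2C(=O)OC)ccc2c(CC)cccc12`: 1.8 ug/mL

In a functional assay on KB cells (Homo sapiens) for cytotoxicity, read by MTT assay, with a stated time of 72 h (on this read-out lower numbers stand for an effect already at smaller amounts and higher numbers for an effect only at larger amounts of compound), compound 1 gives 1.7 ug/mL. Compound 3 gives 1.8 ug/mL in this assay. For compound 2 the result is only a limit, > 10 ug/mL.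

Among the two numbers, compound 3 holds the highest, with compound 1 nearest: a 1.1-fold higher number from compound 1 to compound 3 (0.02 log units; within the scatter), a change that stays within the scatter. Among the measured compounds shown here, the single value that is not a number is the one of compound 2, which sits at the limit of > 10 ug/mL in this assay, at which 1 of the 3 values shown sits.

Compound 4 `CCOc1c(-c2occ(C)c2CO)ccc2c(CC)cccc12` differs from compound 3 in one place: hydroxymethyl in place of methoxycarbonyl on an aromatic carbon. For the measured compounds named here, the only measured step that touches the methoxycarbonyl group is an at least 5.8-fold higher number from compound 1 to compound 2 (0.76 log units; beyond the scatter), where exchanging the methoxy on the carbonyl carbon for methylamino cost a loss beyond the scatter. The change from compound 3 to compound 4 removes the carbonyl altogether and brings in a hydrogen-bond donor, so a loss of similar or larger size in this assay is expected, with a real chance that only a limit is reported. The expected step is a 3.9-fold higher number from compound 3 to compound 4 (0.59 log units; beyond the scatter). Compound 4 is therefore estimated at 7 ug/mL, with a range from 2.5 ug/mL to 20 ug/mL.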

Compound 4, concentration for half-maximal effect: > 10 ug/mL
Compound 4: no number, only a limit; the forecaster's own chance of this, stated with the estimate: 40%; middle value at least 1.4-fold (0.15 log units) from the limit.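

In this assay, hydroxymethyl in place of methoxycarbonyl on this aromatic carbon of the five-membered ring gives an at least 5.5-fold higher number from compound 3 to compound 4 (0.74 log units; beyond the scatter). Among the compounds shown here, the only earlier step at this group, an at least 5.8-fold higher number from compound 1 to compound 2 (0.76 log units; beyond the scatter), kept the carbonyl and changed only what it carries, whereas this one removes the carbonyl altogether, and the loss is again beyond the scatter. Each of the two exchanges, read against its own methoxycarbonyl partner, therefore ends without a number, and for compound 4 the result is only a limit, which fixes no size for the loss beyond the lower bound in its step: the limit of > 10 ug/mL in this assay, at which 2 of the 4 values shown sit.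

The compounds shown leave open whether the carbonyl or the hydroxyl matters more here, a question that a carboxylic acid, a methyl ketone or a methoxymethyl group on this carbon would help to separate. They also leave open how a longer ester, such as an ethyl or isopropyl ester, would read in this assay, and whether any group at this carbon can match the methoxycarbonyl of compound 3.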